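Inactive Core Probed with an Amide-Linked Aryl Group

The compounds below may be only part of what the source reports. "The series", "measured", "known", "first", "only" and "open" are said of these compounds alone.

Compound 1 `CCCCCCCCn1cc(COC2(C(F)(F)F)Oc3ccccc3C=C2C(=O)OCC)nn1`: > 150000 nM
Compound 2 `O=C(O)C1=Cc2ccccc2OC1(OCc1cc(-c2ccc3ccccc3c2)no1)C(F)(F)F`: 141000 nM

In a functional assay on DU-145 cells (Homo sapiens) for inhibition, read by MTT assay, with a stated time of 24 h (on this read-out lower numbers stand for stronger inhibition and higher numbers for weaker inhibition), compound 1 gives > 150000 nM, which is a limit of the assay rather than a number (the limit of > 150000 nM in this assay, at which 1 of the 2 values shown sits). Compound 2 gives 141000 nM in this assay. Compound 3, `CCOC(=O)C1=Cc2ccccc2OC1(OCc1cn(CC(=O)Nc2ccc(OC)cc2)nn1)C(F)(F)F`, differs from compound 1 by (4-methoxyphenyl)carbamoyl in place of heptyl on a saturated chain carbon bound to an aromatic nitrogen. Among the compounds with values here, no measured step covers this kind of change, so the step of an at least 1.1-fold lower number from compound 1 to compound 3 (0.06 log units; that floor lies within the scatter) is expected to stay within the scatter, with no real gain or loss. Compound 3 is therefore estimated at 130000 nM, with a range from 40000 nM to 300000 nM.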

Compound 3, half-maximal inhibitory concentration: 32700 nM
Compound 3: middle estimate off by 4.0-fold (0.60 log units), on the high side; the whole stated range lies above it.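

Putting (4-methoxyphenyl)carbamoyl in place of heptyl on a saturated chain carbon bound to an aromatic nitrogen gives an at least 4.5-fold lower number from compound 1 to compound 3 (0.66 log units; beyond the scatter), so the number in this assay does respond to the group at this position. The full size of this step cannot be read, since the value of compound 1 is a limit of the assay: the limit of > 150000 nM in this assay, at which 1 of the 3 values shown sits.

The amide and the aromatic ring enter together, so the compounds shown do not tell which of them accounts for the step. Going by these compounds, whether an amine or a carboxylic acid in place of the methoxy group would keep the step also stays open.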